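Swapping the methylbenzyl for a nitrobenzyl group

The source may report more compounds than this note shows. Statements on the series, on what has been measured and on what is new or still open speak of the compounds shown alone.

Measured compounds:
Compound 1, `COc1cccc(OC)c1OCCNCCOc1ccccc1OCc1cccc(Cl)c1`: in a functional assay on PC-3 cells (Homo sapiens) for cytotoxicity, read by sulforhodamine B assay (a higher number here means a weaker inhibitor of growth, a lower number a stronger inhibitor of growth), compound 1 gives 5900 nM.
Compound 2, `COc1cccc(OC)c1OCCNCCOc1ccccc1OCc1cccc(C)c1`: in this assay compound 2 gives 12000 nM.

Going by the values given here, of the two numbers measured, compound 2 stands at the higher one, so it is the weaker growth inhibitor of the pair; its only neighbour is compound 1, and the step of a 2.0-fold higher number from compound 1 to compound 2 (0.31 log units; beyond the scatter) separates them. That step, which only exchanged one small group on the benzyl ring, is the whole of what the measurements say about changes at that ring.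

Compound 3, `COc1cccc(OC)c1OCCNCCOc1ccccc1OCc1ccccc1[N+](=O)[O-]`, has not yet been measured. It differs from compound 2 by 2-nitrophenyl in place of 3-methylphenyl on a saturated chain carbon bound to an oxygen on an aromatic ring. Among the compounds with values here, no measured step covers this change directly; the single step at hand, a 2.0-fold higher number from compound 1 to compound 2 (0.31 log units; beyond the scatter), moved the number only modestly when the benzyl ring was altered, and nothing here points to a larger effect in either direction. The expectation for compound 3 is therefore a step of a 1.5-fold lower number from compound 2 to compound 3 (0.18 log units; within the scatter) that stays within the scatter, and compound 3 is estimated at 8000 nM, with a range from 3000 nM to 22000 nM.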

Compound 3, concentration for 50% growth inhibition: 13200 nM
Compound 3: the middle estimate sits 1.7-fold (0.22 log units) below what was measured; low and high end bracket the measured number.
By their numbers in this assay, from the lowest: compound 1; then compounds 2 and 3 (each within the scatter of the next).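

In this assay, putting 2-nitrophenyl in place of 3-methylphenyl on a saturated chain carbon bound to an oxygen on an aromatic ring gives a 1.1-fold higher number from compound 2 to compound 3 (0.04 log units; within the scatter) and so leaves the two compounds indistinguishable, even though the entering group is larger and brings two hydrogen-bond acceptors where the leaving group has none. Measured against the chloro-bearing ring, the same nitro-bearing ring gives a 2.2-fold higher number from compound 1 to compound 3 (0.35 log units; beyond the scatter), a modest step beyond the scatter, so among these three compounds the 3-chlorophenyl ring of compound 1 alone stands apart from the other two, with the lowest number and the strongest growth inhibition. Nothing available here offers a reason for this pattern in the numbers.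

The step to compound 3 changed both the group and its place on the ring at once, so these compounds cannot separate the two effects, and a pair such as 3-nitrophenyl against 2-nitrophenyl would be needed to do so. As far as these compounds go, it also remains open how this position would respond to a plain unsubstituted benzyl ring, or to a ring carrying an amine or a carboxylic acid.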